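Anilide variation on the proline sulfonamide series

A few compounds are considered here, and "the series" means these few. Any claim that something is new, unique, unknown or untested is made for them only; others in the source may bear on it.

Compound 1 `Cc1cccc(NC(=O)[C@@H]2CCCN2S(=O)(=O)c2cccc3cccnc23)c1` serves as the reference point. In an ADME assay on HEp-2 cells (Homo sapiens) for cytotoxicity (on this read-out higher numbers stand for lower toxicity in this test and lower numbers for higher toxicity in this test), compound 1 gives 25500 nM, the highest of the two numbers in the set. Compound 3 `Cc1ccc(Cl)cc1NC(=O)[C@@H]1CCCN1S(=O)(=O)c1cccc2cccnc12` gives 10000 nM, a step of a 2.6-fold lower number from compound 1 to compound 3 (0.41 log units; beyond the scatter). Compound 2 `Cc1cccc(C)c1NC(=O)[C@@H]1CCCN1S(=O)(=O)c1cccc2cccnc12` returns only a limit of the assay, > 50000 nM, consistent with the limit of > 50000 nM in this assay, at which 1 of the 3 values shown sits. The step of an at least 1.9-fold higher number from compound 1 to compound 2 (0.29 log units; that floor lies within the scatter) has a floor inside the scatter, whereas an at least 5.0-fold lower number from compound 2 to compound 3 (0.69 log units; beyond the scatter) lies beyond it.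

Compound 4 `COc1ccc(C)c(NC(=O)[C@@H]2CCCN2S(=O)(=O)c2cccc3cccnc23)c1` is not yet measured. It differs from compound 1 in one place: 5-methoxy-2-methylphenyl in place of 3-methylphenyl on an amide-type nitrogen. The relevant measured step is that to compound 3, where 5-chloro-2-methylphenyl replaced the same 3-methylphenyl and the number fell modestly. A fall of comparable size is expected because a 2.6-fold lower number from compound 1 to compound 3 (0.41 log units; beyond the scatter) arose from a closely related substitution pattern. The expected step is a 1.7-fold lower number from compound 1 to compound 4 (0.23 log units; within the scatter). Compound 4 is therefore expected to give 15000 nM, with a range from 6000 nM to 40000 nM.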

Compound 4, half-maximal cytotoxic concentration: 44200 nM
Compound 4: middle estimate off by 2.9-fold (0.47 log units), on the low side, and the stated range ends below it.
By their numbers in this assay, from the lowest: compound 3; then compounds 1 and 4 (each within the scatter of the next). At a limit, above all of these: compound 2.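

In this assay, 5-methoxy-2-methylphenyl in place of 3-methylphenyl on the amide-type nitrogen gives no readable change (a 1.7-fold higher number from compound 1 to compound 4 (0.24 log units; within the scatter)). Methoxy in place of chloro on an aromatic carbon gives the clear separation (a 4.4-fold higher number from compound 3 to compound 4 (0.65 log units; beyond the scatter)), so the lower number of compound 3 does not extend to every 2-methylphenyl variant carrying a second substituent. Compound 2 stands at a limit of the assay, and the step (an at least 1.1-fold lower number from compound 2 to compound 4 (0.05 log units; that floor lies within the scatter)) gives no firm order.

From the compounds shown here alone, whether an amine or a carboxylic acid in place of the methoxy would keep the number this high remains open.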